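The source may report more compounds than this note shows. Statements on the series, on what has been measured and on what is new or still open speak of the compounds shown alone.

Among the measured compounds shown here, in a functional assay on HCT-116 cells (Homo sapiens) for inhibition, read by CCK-8 assay, with a stated time of 48 h (a lower number here means a stronger inhibitor, a higher number a weaker inhibitor), compound 1 (`CCN1CCN(C(=S)SCC(=O)N(Cc2ccc(OC)cc2)c2cc(OC)c(OC)c(OC)c2)CC1`) gives 7700 nM, the lower of the two numbers measured so far. Compound 2 (`COc1ccc(CN(C(=O)CSC(=S)N2CCc3ccccc3C2)c2cc(OC)c(OC)c(OC)c2)cc1`) gives 15900 nM. For the measured compounds named here, the only measured step, a 2.1-fold higher number from compound 1 to compound 2 (0.31 log units; beyond the scatter), places 1,2,3,4-tetrahydroisoquinolin-2-yl where 4-ethylpiperazin-1-yl stood on a thiocarbonyl carbon, and it is modest. Compound 3 (`COc1ccc(CN(C(=O)CN2CCN(C(C)=O)CC2)c2cc(OC)c(OC)c(OC)c2)cc1`) has not yet been measured. Its difference from compound 1 reaches further: a group of 9 heavy atoms (6 carbon, 2 nitrogen, 1 oxygen; one six-membered non-aromatic ring with 2 hetero atoms) in place of a group of 11 heavy atoms (7 carbon, 2 nitrogen, 2 sulfur; one six-membered non-aromatic ring with 2 hetero atoms), on a saturated chain carbon bound to a carbonyl carbon. Going by the values given here, the thiocarbonyl carbon itself is gone here, so the measured step offers only a loose guide, and no measured compound lacks that carbon. Taking that step as the only available yardstick, a modest rise in this assay is expected, with wide uncertainty. The estimate corresponds to an expected step of a 2.1-fold higher number from compound 1 to compound 3 (0.32 log units; beyond the scatter). For compound 3 the estimated value is 16000 nM, with an expected range of 6000 nM to 40000 nM.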

Compound 3, half-maximal inhibitory concentration: > 20000 nM
Compound 3 gave a limit, no number; the forecaster's own chance of this, stated with the estimate: 15%; at least 1.2-fold (0.09 log units) between middle value and limit.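

Swapping the sulfur-bearing group for 4-acetylpiperazin-1-yl, on a saturated chain carbon bound to a carbonyl carbon, gives an at least 2.5-fold higher number from compound 1 to compound 3 (0.41 log units; beyond the scatter) in this assay. Compound 3 has a limit of the assay, not a number: the limit of > 20000 nM in this assay, at which 1 of the 3 values shown sits. The earlier step changed only the group on the thiocarbonyl carbon, whereas compound 3 is the one compound shown without that carbon and without sulfur, and this change weakens the reading relative to compound 1 by an amount with no known upper end.

This single change removes the thiocarbonyl carbon and both sulfur atoms and also puts acetyl where ethyl stood, so the compounds shown cannot say which of these parts matters. Going by these compounds, how a morpholin-4-yl or dimethylamino group would read at that chain carbon also remains open.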